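The source may report more compounds than this note shows. Statements on the series, on what has been measured and on what is new or still open speak of the compounds shown alone.

Working notes on the series. Two compounds share the core and carry a mid-sized chain ending in a piperazinone; compound 1 is `CCO/N=C/c1ccc(OCCC(C)CCN2CCN(c3ccccc3)C2=O)cc1` and compound 2 is `CC(CCOc1ccc(/C=N/O)cc1)CCN1CCN(c2ccnc(N)c2)C1=O`. In an ADME assay on RD cells (Homo sapiens) for cytotoxicity, read by MTT assay, with a stated time of 24 h (a higher number here means that more compound is tolerated, a lower number that less compound is tolerated), compound 1 reaches only the limit of the assay, > 100000 nM. In this assay compound 2 likewise reaches only the limit, > 100000 nM, so no number stands for it. Both values shown therefore sit at the limit of > 100000 nM in this assay, at which 2 of the 2 values shown sit, and compound 2 cannot be placed above or below compound 1 on what is shown.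

Compound 3 is `Cc1nc(-c2ccc(OCCC(C)CCN3CCN(c4ccnc(N)c4)C3=O)cc2)no1`. It differs from compound 2 as follows: a group of 6 heavy atoms (3 carbon, 2 nitrogen, 1 oxygen; one five-membered aromatic ring with 3 hetero atoms) in place of a group of 3 heavy atoms (1 carbon, 1 nitrogen, 1 oxygen; no ring), on an aromatic carbon. Among the measured compounds shown here, no step between measured compounds is recorded, so the effect of this change can only be expected, not read from the pair. Since compound 2 gives > 100000 nM and compound 1 gives > 100000 nM, both limits, the expectation is that compound 3 again sits at or near the limit; the step of a number no higher from compound 2 to compound 3 (the limit leaves the size open) is estimated as none beyond the scatter. The estimate for compound 3 in this assay is 100000 nM, with a range from 50000 nM to 300000 nM, most likely reported as a limit once more.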

Compound 3, half-maximal cytotoxic concentration: 66100 nM
Estimate against measurement, compound 3: 1.5-fold (0.18 log units) above; low and high end bracket the measured number.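

In this assay, placing 5-methyl-1,2,4-oxadiazol-3-yl on an aromatic carbon of a six-membered aromatic ring of carbon only, para to a large group, gives an at least 1.5-fold lower number from compound 2 to compound 3 (0.17 log units; that floor lies within the scatter). Among the compounds shown here, compound 3 is the first compound with a number rather than a limit, 66100 nM, so this position is one where a change of group can yield a measured number. The size of the step stays open, and it cannot be called a real drop on what is shown, because the starting value is a limit and the floor of the step lies within the scatter: the limit of > 100000 nM in this assay, at which 2 of the 3 values shown sit.

The compounds shown leave open whether the five-membered aromatic ring itself or its methyl group accounts for the number seen for compound 3, and whether a nitrile, a carboxylic acid or a simple ester at the same place would stay at the limit or not. For the compounds shown here, they also leave open how 5-methyl-1,2,4-oxadiazol-3-yl behaves when the far end of the chain carries a group other than the one in compound 3.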